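This account rests on a few compounds, and the source may have more. Where it says the series, first, only, none or still open, it means among the compounds named here.

Working notes on the series. Among the compounds with values here, compound 2 `COc1ccccc1/C=C(/SCc1ccc(C)cc1)C(=O)c1ccc(Cl)cc1` gives 10000 nM in a functional assay on DU-145 cells (Homo sapiens) for inhibition, read by trypan blue exclusion, with a stated time of 96 h (a lower number here means a stronger inhibitor of growth, a higher number a weaker inhibitor of growth), and stands with the lowest of the two numbers measured so far. Within the data shown here, its only neighbour, compound 1 `CSc1ccc(/C=C(/SCc2ccc(C)cc2)C(=O)c2ccc(Cl)cc2)cc1`, gives 25000 nM; the single measured step, a 2.5-fold lower number from compound 1 to compound 2 (0.40 log units; beyond the scatter), came from exchanging the aryl group on the double-bonded chain carbon bound to a double-bonded chain carbon, with the rest of the shared core held fixed.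

Compound 3 `Cc1ccc(CS/C(=C/c2cccc(Cl)c2Cl)C(=O)c2ccc(Cl)cc2)cc1` has not been measured. Its change from compound 2 is 2,3-dichlorophenyl in place of 2-methoxyphenyl on a double-bonded chain carbon bound to a double-bonded chain carbon. Among the measured compounds shown here, the step from compound 1 to compound 2 bears on it only loosely: it shows that swapping the aryl group at this place moves the number by a modest amount, but no measured compound carries a chlorine-bearing aryl group at this place, so the direction cannot be read from the data. The expectation is therefore a step of no change at the digits printed from compound 2 to compound 3 (within the scatter), which is within the scatter in either direction. Compound 3 is estimated at 10000 nM, with a range from 3000 nM to 30000 nM in this assay.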

Compound 3, concentration for 50% growth inhibition: 25000 nM
Compound 3: middle estimate off by 2.5-fold (0.40 log units), on the low side; measured number inside the range.
By their numbers in this assay, from the lowest: compound 2; then compounds 1 and 3 (each within the scatter of the next).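

In this assay, the aryl group on a double-bonded chain carbon bound to a double-bonded chain carbon now has three measured forms, and the result of a 2.5-fold higher number from compound 2 to compound 3 (0.40 log units; beyond the scatter) shows that 2,3-dichlorophenyl does not keep the number seen with 2-methoxyphenyl. The exchange of 4-(methylsulfanyl)phenyl for 2,3-dichlorophenyl gives no change at the digits printed from compound 1 to compound 3 (within the scatter) so two differently substituted aryl groups cannot be told apart here, while compound 2 is separated from both by steps beyond the scatter. No measurement beyond these growth-inhibition numbers is available to account for that separation.

Whether the lower number of compound 2 goes with the methoxy group itself or with its placement remains open, as the compounds shown include neither 3-methoxyphenyl nor 4-methoxyphenyl at this place. Also open, going by these compounds, is how an aryl group carrying an amine or a carboxylic acid would read here, and whether any group at this place can bring the number well under that of compound 2.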